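Methoxy to chloro in a small growth-inhibition series

This account rests on a few compounds, and the source may have more. Where it says the series, first, only, none or still open, it means among the compounds named here.

Going by the values given here, in an ADME assay on HEK-293T cells (Homo sapiens) for inhibition, read by CCK-8 assay, with a stated time of 48 h, tested at 20 uM (on this read-out higher numbers stand for more inhibition of growth at the one concentration tested and lower numbers for less inhibition of growth), only two compounds have numbers so far. Compound 1 (`COc1ccc(Cc2nnc(NC(=O)/C(C#N)=C/c3ccccc3OS(=O)(=O)c3ccc(Cl)cc3)s2)cc1`) gives 34% and compound 2 (`COc1ccc(S(=O)(=O)Oc2ccccc2/C=C(\C#N)C(=O)Nc2nnc(Cc3ccccc3)s2)cc1`) gives 23% as the lower of the two numbers, a gap that lies beyond the usual scatter.

Compound 3 (`N#C/C(=C\c1ccccc1OS(=O)(=O)c1ccc(Cl)cc1)C(=O)Nc1nnc(Cc2ccccc2)s1`) has not yet been measured. It differs from compound 2 in one place (chloro in place of methoxy on an aromatic carbon), with chloro in place of methoxy on an aromatic carbon, para to a large group, so that 4-methoxyphenyl becomes 4-chlorophenyl.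

Among the compounds with values here, no step between measured compounds that differ in one place is available, so the data offer no direct guide to this change. Compound 1 also holds a 4-chlorophenyl and stands at 34% as the higher of the two numbers, so a small upward move is expected in this assay that may well stay within the scatter. The estimated change is a number 7 percentage points higher from compound 2 to compound 3 (within the scatter) on this thin evidence. For compound 3 the expected value is 30% with an estimated range from 17% to 44% in this read-out.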

Compound 3, percent growth inhibition at one concentration: 25%
For compound 3 the middle estimate is 5 percentage points above the measured one; measured number inside the range.
By their numbers in this assay, from the lowest: compounds 2, 3 and 1 (each within the scatter of the next, the first and the last beyond it).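

In this assay the change from 4-methoxyphenyl to 4-chlorophenyl can now be read directly, on an aromatic carbon para to a large group: the step is a number 2 percentage points higher from compound 2 to compound 3 (within the scatter) and shows that chloro in place of methoxy at this position leaves the read-out within the usual scatter. A second single change, the removal of a methoxy group elsewhere in the molecule, gives a number 9 percentage points lower from compound 1 to compound 3 (within the scatter) and also stays within the scatter, so neither change taken alone separates its pair of compounds. Nothing available explains either step or gives a measured property of these groups.

What the compounds shown leave open is how far this position tolerates groups of a different kind, such as an amine, a carboxylic acid or a longer alkoxy chain in place of chloro or methoxy. On these data alone, it also remains open whether either step would hold at another concentration, since each compound has a number at only one concentration and these two steps rest on one pair of compounds each.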